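A few compounds are considered here, and "the series" means these few. Any claim that something is new, unique, unknown or untested is made for them only; others in the source may bear on it.

Measured so far, in an ADME assay on Huh-7 cells (Homo sapiens) for cytotoxicity; a higher number here means that more compound is tolerated, a lower number that less compound is tolerated:

Compound 1 `CN1CCN(CCNCc2cn(-c3ccc(F)cc3F)nc2-c2ccccc2)CC1` — > 20000 nM
Compound 2 `CN1CCN(CCNCc2cn(-c3ccc(F)cc3F)nc2C2CCCCC2)CC1` — > 20000 nM
Compound 3 `COC(=O)c1ccc(-c2nn(-c3ccc(F)cc3F)cc2CNCCN2CCN(C)CC2)cc1` — > 20000 nM

Compound 3 stands at a limit of this assay, not at a number. The same holds for compound 1 and for compound 2, so that the limit of > 20000 nM in this assay, at which 3 of the 3 values shown sit, is the whole of what the numbers show. The step that the two limits leave unreadable from compound 1 to compound 3 is therefore unreadable in size, as are a step that the two limits leave unreadable from compound 1 to compound 2 and a step that the two limits leave unreadable from compound 2 to compound 3; none of the three measured steps reports a direction or a magnitude.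

Compound 4 `CN1CCN(CCNCc2cn(-c3ccc(F)cc3F)nc2-c2ccc(C(F)(F)F)cc2)CC1` differs from compound 3 by trifluoromethyl in place of methoxycarbonyl on an aromatic carbon. Among the compounds with values here, no measured step bears on this change beyond the three unreadable ones, and the exchange of cyclohexyl for phenyl and the addition of methoxycarbonyl both left the value at the limit. The account therefore expects no step beyond the scatter in this assay, with the likeliest outcome that compound 4 is again reported only as a limit.

On that basis compound 4 is estimated at 25000 nM, between 12000 nM and 60000 nM. The step that the limit leaves unreadable from compound 3 to compound 4 is expected to be negligible.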

Compound 4, half-maximal cytotoxic concentration: 20000 nM
Compound 4: the middle estimate sits 1.3-fold (0.10 log units) above what was measured, within the range that was stated.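

Compound 4 is the only one of the four compounds shown to give a number rather than a limit in this assay, at 20000 nM. Trifluoromethyl in place of methoxycarbonyl, on an aromatic carbon para to a large group, thus gives a number no higher from compound 3 to compound 4 (the limit leaves the size open), and the same reading holds for a number no higher from compound 2 to compound 4 (the limit leaves the size open) and for a number no higher from compound 1 to compound 4 (the limit leaves the size open). None of these steps can be read in size, since the other three values are limits: the limit of > 20000 nM in this assay, at which 3 of the 4 values shown sit.

Going by these compounds, whether compound 4 truly differs from the other three compounds stays open, as does what an amine or a carboxylic acid at this place would give in this assay. The compounds shown also give no number other than that of compound 4, so no change that clearly moves the value is known from them.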